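The source may hold more compounds than are shown below. What is called first, only, known or untested is meant among the compounds shown, and "the series" means these compounds.

In a functional assay on SK-OV-3 cells (Homo sapiens) for cytotoxicity, read by spectrophotometry, with a stated time of 72 h (a higher number here means a weaker inhibitor, a lower number a stronger inhibitor), compound 1 (`COc1ccc(-c2cccc(=O)n2-c2cc(OC)c(OC)c(OC)c2)cc1`) reads < 10 nM, which is a limit of the assay and not a number. Compound 2 (`COc1ccc(-c2cccc(=O)n2-c2cc(OC)c(OC)c(OC)c2)cc1C`) gives 583 nM, and compound 3 (`COc1ccc(-n2c(-c3cc(OC)c(OC)c(OC)c3)cccc2=O)cc1OCc1ccccc1`) gives 25500 nM, the highest of the three values. Compound 4 (`COc1ccc(-n2c(-c3cc(OC)c(OC)c(OC)c3)cccc2=O)cc1`) has hydrogen in place of benzyloxy on an aromatic carbon, ortho to a methoxy group: hydrogen in place of benzyloxy on an aromatic carbon. Among the measured compounds shown here, the one measured step that bears on this is an at least 58-fold higher number from compound 1 to compound 2 (1.76 log units; beyond the scatter), with methyl in place of hydrogen on an aromatic carbon. That step was large, and it points to hydrogen giving the lower number in this assay. For the measured compounds named here, compound 3 and compound 4 arrange their substituents on the shared core differently from compound 1 and compound 2, and no measured step covers that difference, so the transfer is uncertain. A large fall in this assay is therefore expected, and the expected change is a 170-fold lower number from compound 3 to compound 4 (2.23 log units; beyond the scatter). For compound 4 the estimated value is 150 nM, with an expected range of 10 nM to 3000 nM.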

Compound 4, half-maximal inhibitory concentration: 1540 nM
For compound 4 the middle estimate is 10-fold (1.01 log units) below the measured one, within the range that was stated.
By their numbers in this assay, from the lowest: compound 2; then compound 4; then compound 3. At a limit, below all of these: compound 1.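

In this assay, hydrogen in place of benzyloxy on an aromatic carbon, ortho to a methoxy group, gives a 17-fold lower number from compound 3 to compound 4 (1.22 log units; beyond the scatter). Among the compounds shown here, this is the first step measured within the arrangement of substituents shared by compound 3 and compound 4, and it shows that a change at this one place is enough to move the value beyond the scatter. Hydrogen now gives the lower number in both measured steps, but these are only two pairs, with different groups and different arrangements on the shared core.

From the compounds shown here alone, whether a hydroxyl group or an amine at this place would give a number closer to that of hydrogen or of benzyloxy stays open. Compound 1 reads as a limit and not a number, so the full size of the methyl step also stays open: the limit of < 10 nM in this assay, at which 1 of the 4 values shown sits.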